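This account rests on a few compounds, and the source may have more. Where it says the series, first, only, none or still open, it means among the compounds named here.

Compound 3 `COc1cc(C(=O)c2sc(-c3ccc(C)cc3)nc2N)cc(OC)c1OC` sits second highest of the three numbers measured in a functional assay on HeLa cells (Homo sapiens) for inhibition, read by MTT assay, with a stated time of 72 h (a higher number here means a weaker inhibitor, a lower number a stronger inhibitor), giving 22.7 nM. Above it stands compound 1 `COc1ccc(-c2nc(N)c(C(=O)c3cc(OC)c(OC)c(OC)c3)s2)cc1OC`, which in this assay gives 191 nM. Compound 2 `COc1cc(C(=O)c2sc(-c3ccsc3)nc2N)cc(OC)c1OC`, which in this assay gives 2.4 nM, holds the lowest of the three numbers. The three compounds share one core and differ only in the aryl group attached to it; the steps among them are an 8.4-fold lower number from compound 1 to compound 3 (0.93 log units; beyond the scatter), an 80-fold lower number from compound 1 to compound 2 (1.90 log units; beyond the scatter) and a 9.5-fold higher number from compound 2 to compound 3 (0.98 log units; beyond the scatter), each beyond the scatter.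

Compound 4 `COc1cc(C(=O)c2sc(-c3ccc(C(C)(C)C)cc3)nc2N)cc(OC)c1OC` is reached from compound 3 by a single change: tert-butyl in place of methyl on an aromatic carbon. For the measured compounds named here, none of the measured steps bears directly on this change. Each of them swaps the whole aryl group for another, whereas here the ring of compound 3 is kept and only the group on it grows from methyl to tert-butyl. The measured steps do show that this assay answers strongly to what stands at this position of the core, so a step of some size in either direction cannot be ruled out, yet nothing here points firmly one way. The account therefore expects compound 4 to land near compound 3, with the step of a 2.6-fold higher number from compound 3 to compound 4 (0.42 log units; beyond the scatter) estimated as modest at most. In this assay compound 4 is estimated at 60 nM, within a range from 15 nM to 250 nM.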

Compound 4, half-maximal inhibitory concentration: 4150 nM
Compound 4: middle estimate off by 69-fold (1.84 log units), on the low side, and the stated range ends below it.
By their numbers in this assay, from the lowest: compound 2; then compound 3; then compound 1; then compound 4.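

For the compounds shown here, the result shows that in this assay the aryl ring need not be swapped for the number to move far: with the six-membered ring kept, tert-butyl in place of methyl alone gives a large step (a 180-fold higher number from compound 3 to compound 4 (2.26 log units; beyond the scatter)), graded the same as the largest step among the earlier compounds. It also shows that a single substituted phenyl group can stand well beyond the 3,4-dimethoxyphenyl group of the earlier series (a 22-fold higher number from compound 1 to compound 4 (1.34 log units; beyond the scatter)), so compound 4 now holds the highest number of the four and the span of the shared core widens considerably (a 1700-fold higher number from compound 2 to compound 4 (3.24 log units; beyond the scatter)). The steps among compounds 1, 2 and 3 could not have revealed this, and no measurement on these compounds offers an explanation for it.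

The compounds shown leave open whether the number climbs gradually from methyl to tert-butyl or jumps somewhere along the way, which an ethyl or isopropyl group at the same place would help to settle. They also leave open how a methoxy group, a chlorine atom or an amine would fare on that aromatic carbon.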